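Swapping two chlorines for two fluorines on a chalcone-pyrazole

The source may report more compounds than this note shows. Statements on the series, on what has been measured and on what is new or still open speak of the compounds shown alone.

Three compounds share a core built from a pyrazole linked to an enone, and all three were tested in a functional assay on M14 cells (Homo sapiens) for cytotoxicity, read by sulforhodamine B assay, with a stated time of 48 h, tested at 100 uM; on this read-out lower numbers stand for a stronger effect and higher numbers for a weaker effect at the one concentration tested. Compound 1 `COc1cc(-c2cc(/C=C/C(=O)c3ccc(Cl)c(Cl)c3)[nH]n2)cc(OC)c1OC` carries a 3,4-dichlorophenyl on the carbonyl carbon; in this assay compound 1 gives 20%. Compound 2 `COc1ccc(-c2cc(/C=C/C(=O)c3cc(OC)c(OC)c(OC)c3)[nH]n2)cc1OC` gives -74% in this assay, and compound 3 `COc1ccc(-c2cc(/C=C/C(=O)c3ccc(N)cc3)[nH]n2)cc1` gives -71%. Among these three numbers compound 1 stands highest, meaning the weakest effect of the set at the single concentration tested; its nearest neighbour is compound 3, whose number lies well beyond the scatter below it, and compound 2 lies further still.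

The step to compound 4 `COc1cc(-c2cc(/C=C/C(=O)c3ccc(F)c(F)c3)[nH]n2)cc(OC)c1OC` changes only one place: 3,4-difluorophenyl in place of 3,4-dichlorophenyl on a carbonyl carbon. Among the compounds with values here, no measured pair shows this particular exchange, so the size of its step in this assay has to be expected rather than read from a neighbour. With the two measured companions of compound 1 both far lower, the direction remains uncertain, and a step within the scatter or a modest move downward both seem plausible.

Compound 4 is therefore estimated at 15%, with a range from -40% to 50%. The step this estimate implies, a number 5 percentage points lower from compound 1 to compound 4 (within the scatter), is expected to be small.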

Compound 4, a percentage reported as activity, at one concentration (the size of the read-out at that concentration, not a potency): -38%
Estimate against measurement, compound 4: 53 percentage points above; the measured number falls inside the stated range.
By their numbers in this assay, from the lowest: compounds 2 and 3 (each within the scatter of the next); then compound 4; then compound 1.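

In this assay, within the data shown here, replacing 3,4-dichlorophenyl with 3,4-difluorophenyl on the carbonyl carbon produces a step of a number 58 percentage points lower from compound 1 to compound 4 (beyond the scatter) and so gives the first direct reading at this position: the two halogens alone can change the result by far more than the usual scatter. The two groups match in heavy-atom count, in their carbon-only aromatic ring and in carrying no net charge, and the rest of the structure is unchanged, so the whole step belongs to this one exchange of chlorine for fluorine. The data offer no independent measurement that would explain the size of this step.

From the compounds shown here alone, a single pair cannot show whether the response at this position follows any trend across halogens, and it remains open how a 3,4-dibromophenyl, a 4-fluorophenyl carrying only one fluorine or an unsubstituted phenyl on the same carbonyl carbon would fall relative to these two compounds. Going by these compounds, it is also open whether the same exchange would produce a step of similar size on a different substitution pattern of the shared core, such as one carrying a carboxylic acid or an amine.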